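The source may report more compounds than this note shows. Statements on the series, on what has been measured and on what is new or still open speak of the compounds shown alone.

Working notes on the series. Of the compounds shown here, three on one shared core have numbers so far: compound 1 is `CC(=O)OC[C@H]1O[C@@H](n2cc(CN3C(=O)/C(=C\C=C\c4ccccc4)c4ccccc43)nn2)[C@H](OC(C)=O)[C@@H](OC(C)=O)[C@@H]1OC(C)=O`, compound 2 is `CC(=O)OC[C@H]1O[C@@H](n2cc(CN3C(=O)/C(=C\c4ccc5ccccc5c4)c4ccccc43)nn2)[C@H](OC(C)=O)[C@@H](OC(C)=O)[C@@H]1OC(C)=O`, and compound 3 is `CC(=O)OC[C@H]1O[C@@H](n2cc(CN3C(=O)/C(=C\c4cccs4)c4ccccc43)nn2)[C@H](OC(C)=O)[C@@H](OC(C)=O)[C@@H]1OC(C)=O`. In an ADME assay on NIH3T3 cells (Homo sapiens) for cytotoxicity, read by sulforhodamine B assay, with a stated time of 48 h (on this read-out higher numbers stand for weaker inhibition and lower numbers for stronger inhibition), compound 1 gives 25900 nM, compound 2 gives 80000 nM, and compound 3 gives 14600 nM. On these numbers compound 3 stands at the low end, separated from compound 2 by a step of a 5.5-fold lower number from compound 2 to compound 3 (0.74 log units; beyond the scatter), but not separated from compound 1, where the step is a 1.8-fold lower number from compound 1 to compound 3 (0.25 log units; within the scatter). Between the other pair the step is a 3.1-fold higher number from compound 1 to compound 2 (0.49 log units; beyond the scatter).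

Compound 4 is `CC(=O)OC[C@H]1O[C@@H](n2cc(CN3C(=O)/C(=C\c4ccco4)c4ccccc43)nn2)[C@H](OC(C)=O)[C@@H](OC(C)=O)[C@@H]1OC(C)=O`. Relative to compound 3 the change is furan-2-yl in place of thiophen-2-yl on a double-bonded chain carbon bound to a double-bonded ring carbon. Among the compounds with values here, no measured step exchanges one five-membered aromatic ring with 1 hetero atom for another; the two steps that reach this position, a 1.8-fold lower number from compound 1 to compound 3 (0.25 log units; within the scatter) and a 5.5-fold lower number from compound 2 to compound 3 (0.74 log units; beyond the scatter), only show that the group on the double-bonded chain carbon moves the number by a modest span at most. What is counted for the leaving and entering groups is the same apart from the hetero atom. The expected step is therefore a 1.1-fold higher number from compound 3 to compound 4 (0.04 log units; within the scatter), with no direction beyond the scatter claimed. Compound 4 is estimated at 16000 nM in this assay, with an expected range from 6000 nM to 45000 nM.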

Compound 4, half-maximal inhibitory concentration: 13300 nM
For compound 4 the middle estimate is 1.2-fold (0.08 log units) above the measured one; the measured number falls inside the stated range.
By their numbers in this assay, from the lowest: compounds 4, 3 and 1 (each within the scatter of the next); then compound 2.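

In this assay, within the data shown here, the step from thiophen-2-yl to furan-2-yl is the first measured exchange of one five-membered aromatic ring with 1 hetero atom for another, and at a 1.1-fold lower number from compound 3 to compound 4 (0.04 log units; within the scatter) it shows that swapping sulfur for oxygen at this place, on a double-bonded chain carbon bound to a double-bonded ring carbon, leaves the number within the scatter. Furan-2-yl also repeats the split already seen with thiophen-2-yl: the step from naphthalen-2-yl, a 6.0-fold lower number from compound 2 to compound 4 (0.78 log units; beyond the scatter), lies beyond the scatter, while the step from 2-phenylethenyl, a 1.9-fold lower number from compound 1 to compound 4 (0.29 log units; within the scatter), lies within it, so among these four compounds only compound 2 stands apart from the rest. Nothing available speaks to what lies behind these numbers.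

Still open, going by these compounds, is whether a group carrying an amine or a carboxylic acid at this place, or a six-membered ring such as pyridin-2-yl, would stay within the same span of numbers. Only this one place varies across the compounds shown, so it is also unsettled how the number would respond if free hydroxyl groups replaced the acetyl esters on the shared core.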